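Ring change at the aryl substituent of compound 2

This account rests on a few compounds, and the source may have more. Where it says the series, first, only, none or still open, it means among the compounds named here.

Measured compounds in this series:
- compound 1 `COC(=O)c1ccccc1C1CCC(CNc2nccc(C)c2NC(=O)CC#N)CC1`: 385 nM
- compound 2 `COC(=O)C1CCCCC1c1ccc(CNc2nccc(C)c2NC(=O)CC#N)cc1`: 2.2 nM
- compound 3 `COC(=O)C1C2CCC(CC2)C1c1ccc(CNc2nccc(C)c2NC(=O)CC#N)cc1`: 54 nM

In an assay on isolated protein for binding affinity to B1 bradykinin receptor (Homo sapiens) (on this read-out higher numbers stand for weaker inhibition and lower numbers for stronger inhibition), compound 2 gives 2.2 nM, the lowest of the three numbers. Compound 3 gives 54 nM, a number higher than that of compound 2 by a margin beyond the scatter. Compound 1 gives 385 nM, the highest of the three and the furthest from compound 2. Among the compounds with values here, no two of these three compounds differ in one place only, so no single-point step between measured compounds is on hand; the three numbers only show that compound 2 is the strongest binder among them.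

Compound 4 `COC(=O)C1CCCN1c1ccc(CNc2nccc(C)c2NC(=O)CC#N)cc1` is the next compound to be measured in this assay. It differs from compound 2 in one place: 2-(methoxycarbonyl)pyrrolidin-1-yl in place of 2-(methoxycarbonyl)cyclohexyl on an aromatic carbon. The ring attached to the aromatic carbon shrinks, gains a hetero atom and becomes the point of attachment through its nitrogen.

Within the data shown here, with no comparable step among the measured compounds, the expectation is a moderate rise in the number, that is weaker binding, from compound 2 to compound 4 of about a 9.1-fold higher number from compound 2 to compound 4 (0.96 log units; beyond the scatter). For compound 4 in this assay the expected value is 20 nM, with a range from 3 nM to 150 nM.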

Compound 4, inhibition constant: > 5000 nM
Compound 4: no number, only a limit; the forecaster's own chance of this, stated with the estimate: 5%; middle value at least 250-fold (2.39 log units) away from the limit.
By their numbers in this assay, from the lowest: compound 2; then compound 3; then compound 1. At a limit, above all of these: compound 4.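

Within the data shown here, replacing 2-(methoxycarbonyl)cyclohexyl with 2-(methoxycarbonyl)pyrrolidin-1-yl on an aromatic carbon, para to a large group, gives an at least 2200-fold higher number from compound 2 to compound 4 (3.35 log units; beyond the scatter), the first step that differs in one place. In this assay the value of compound 4 is a limit and not a number: the limit of > 5000 nM in this assay, at which 1 of the 4 values shown sits. This position therefore does not accept every ring bearing the methoxycarbonyl group: the group is present in both compound 2 and compound 4, and its presence alone does not preserve the low number of compound 2.

The step changes ring size, adds a ring nitrogen and moves the point of attachment to that nitrogen all at once, and the compounds shown cannot separate these three changes. Open comparisons with compound 2 are 2-(methoxycarbonyl)cyclopentyl, which would change ring size alone, 2-(methoxycarbonyl)piperidin-1-yl, which would keep the six-membered ring but attach through nitrogen, and a carboxylic acid in place of the methyl ester on the cyclohexyl ring.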